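The source may hold more compounds than are shown below. What is called first, only, known or untested is meant among the compounds shown, and "the series" means these compounds.

Compound 2 `COc1cccc(OC)c1OCCNCCOc1ccccc1OCc1cccc(C)c1` gives 12000 nM in a functional assay on PC-3 cells (Homo sapiens) for cytotoxicity, read by sulforhodamine B assay (on this read-out higher numbers stand for weaker inhibition of growth and lower numbers for stronger inhibition of growth), the highest of the two numbers recorded, with compound 1 `COc1cccc(OC)c1OCCNCCOc1ccccc1OCc1ccccc1Cl` nearest at 5400 nM; that step, a 2.2-fold higher number from compound 1 to compound 2 (0.35 log units; beyond the scatter), came with 3-methylphenyl in place of 2-chlorophenyl. Compound 3 `COc1ccccc1COc1ccccc1OCCNCCOc1c(OC)cccc1OC` differs from compound 2 by 2-methoxyphenyl in place of 3-methylphenyl on a saturated chain carbon bound to an oxygen on an aromatic ring. For the measured compounds named here, the single measured step does not involve 2-methoxyphenyl, so it bears on this change only by showing that swapping the group on that chain carbon moved the number modestly. A step within the scatter is therefore expected, a 1.5-fold lower number from compound 2 to compound 3 (0.18 log units; within the scatter). Compound 3 is expected to give 8000 nM, in the range 3000 nM to 20000 nM.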

Compound 3, concentration for 50% growth inhibition: 8900 nM
Beside the measured number, compound 3's estimate is 1.1-fold (0.05 log units) below it; the measured number falls inside the stated range.
By their numbers in this assay, from the lowest: compounds 1, 3 and 2 (each within the scatter of the next, the first and the last beyond it).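

In this assay the swap of 3-methylphenyl for 2-methoxyphenyl on the saturated chain carbon gives a 1.3-fold lower number from compound 2 to compound 3 (0.13 log units; within the scatter) and stays small, as does a 1.6-fold higher number from compound 1 to compound 3 (0.22 log units; within the scatter) with methoxy in place of chloro on an aromatic carbon. Compound 3 thus lies within the scatter of both compound 1 and compound 2, although those two lie beyond it from each other, so these three groups are only weakly separated at this position. Nothing at hand accounts for these steps. Still open, from the compounds shown here alone, is whether an amine or a carboxylic acid in place of methoxy would move the number beyond the scatter.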